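Methoxy added to the phenyl of compound 3

A few compounds are considered here, and "the series" means these few. Any claim that something is new, unique, unknown or untested is made for them only; others in the source may bear on it.

Of the compounds shown here, three have been measured in a functional assay on HT-29 cells (Homo sapiens) for inhibition, read by MTT assay, with a stated time of 72 h; a lower number here means a stronger inhibitor of growth, a higher number a weaker inhibitor of growth. Compound 1 `N#C/C(=C\c1c(F)c(F)c(F)c(F)c1F)C(=O)c1c[nH]c2ccccc12` gives 18000 nM. Compound 2 `N#C/C(=C\c1ccc[nH]1)C(=O)NCc1ccc(Cl)c(Cl)c1` gives 85000 nM. Compound 3 `N#C/C(=C\c1ccccc1)C(=O)NCc1ccc(Cl)c(Cl)c1` gives 70000 nM. Compound 3 therefore stands close to compound 2, the two numbers lying within the scatter, while compound 1 gives a clearly lower number, far enough away to count as a real gap.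

Compound 4 `COc1ccc(/C=C(\C#N)C(=O)NCc2ccc(Cl)c(Cl)c2)cc1` differs from compound 3 in one place: methoxy in place of hydrogen on an aromatic carbon. For the measured compounds named here, no measured step touches this change. Going by the values given here, the only single step on record, a 1.2-fold lower number from compound 2 to compound 3 (0.08 log units; within the scatter), swaps one ring for another on the chain and stays within the scatter; compound 1 differs in too many places to guide the comparison. With nothing pointing either way, the change from compound 3 to compound 4 is expected to stay within the scatter in this assay. Compound 4 is thus estimated at 60000 nM, with a range from 20000 nM to 180000 nM. That estimate corresponds to an expected step of a 1.2-fold lower number from compound 3 to compound 4 (0.07 log units; within the scatter).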

Compound 4, concentration for 50% growth inhibition: > 100000 nM
Compound 4 ended at the assay's limit; the forecaster's own chance of this, stated with the estimate: 20%; middle value at least 1.6-fold (0.22 log units) from the limit.
By their numbers in this assay, from the lowest: compound 1; then compounds 3 and 2 (each within the scatter of the next). At a limit, above all of these: compound 4.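

Methoxy on the aromatic carbon para to a large group brings no sign of stronger growth inhibition in this assay, a change the earlier compounds could not speak to, since compound 3 carries only hydrogen there. The comparison gives an at least 1.4-fold higher number from compound 3 to compound 4 (0.15 log units; that floor lies within the scatter), and likewise an at least 1.1-fold higher number from compound 2 to compound 4 (0.07 log units; that floor lies within the scatter); these are floors, so the true gaps may be larger, but neither floor by itself passes the scatter. Compound 4 stands at a limit of the assay, not at a number: the limit of > 100000 nM in this assay, at which 1 of the 4 values shown sits.

From the compounds shown here alone, whether methoxy truly weakens growth inhibition therefore stays open, since no true value for compound 4 is available. Also open, going by these compounds, is how a hydroxyl, an amine or a carboxylic acid on that same aromatic carbon would read.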